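Octyl-to-aryl swap on the triazole chain of the shared core

This account rests on a few compounds, and the source may have more. Where it says the series, first, only, none or still open, it means among the compounds named here.

Two members of the series have numbers in a functional assay on A549 cells (Homo sapiens) for inhibition, read by MTT assay; a lower number here means a stronger inhibitor, a higher number a weaker inhibitor. Compound 1 `CCCCCCCCn1cc(/C=C/C(=O)c2ccc(N)cc2)nn1` gives 26900 nM. Compound 2 `CCCCCCCCCCn1cc(/C=C/C(=O)c2ccc(NC(=O)CN3CCN(c4ccccc4)CC3)cc2)nn1` gives 52100 nM; the two values lie within the scatter of each other, so neither can be set apart from the other. For the measured compounds named here, no step between measured compounds that differ in one place is available, so the size of any change at this position is unknown.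

Compound 3 `O=C(CN1CCN(c2ccccc2)CC1)Nc1ccc(C(=O)/C=C/c2cn(Cc3ccc(Br)cc3)nn2)cc1` carries 4-bromophenyl in place of nonyl on a saturated chain carbon bound to an aromatic nitrogen. Nothing in the two measured values speaks for a shift in either direction, so from compound 2 to compound 3 no step beyond the scatter is expected in this assay, and the estimated step is a 1.3-fold lower number from compound 2 to compound 3 (0.11 log units; within the scatter). For compound 3 the expected value in this assay is 40000 nM, with a range from 12000 nM to 130000 nM, the width of the range reflecting the absence of any step measured at this position.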

Compound 3, half-maximal inhibitory concentration: 42100 nM
Compound 3: the middle estimate sits 1.1-fold (0.02 log units) below what was measured, within the range that was stated.
By their numbers in this assay, from the lowest: compounds 1, 3 and 2 (each within the scatter of the next).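

For the compounds shown here, this gives the only step read at this position in this assay: with 4-bromophenyl in place of nonyl on a saturated chain carbon bound to an aromatic nitrogen, the change is a 1.2-fold lower number from compound 2 to compound 3 (0.09 log units; within the scatter). The open chain and a group carrying one six-membered aromatic ring and a bromine therefore cannot be told apart in this assay, so the position accepts this change of shape and atom content without a step beyond the scatter. Nothing at hand bears on why the two groups read alike.

Open, on these data alone, is whether a carboxylic acid or a dimethylamino group in place of the bromine, or a chain longer than decyl, would give a step beyond the scatter. Also open, as far as these compounds go, is whether the same swap reads alike on the core of compound 1.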